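This account rests on a few compounds, and the source may have more. Where it says the series, first, only, none or still open, it means among the compounds named here.

Series notes, shared trimethoxyphenyl amide core. Compound 1 `COc1ccc(CN(C(=O)C=C(C)C)c2cc(OC)c(OC)c(OC)c2)cc1O` gives 320 nM in a functional assay on MGC-803 cells (Homo sapiens) for inhibition, read by MTT assay, with a stated time of 48 h; on this read-out lower numbers stand for stronger inhibition and higher numbers for weaker inhibition. Compound 2 `C/C=C/C(=O)N(Cc1ccc(OC)cc1)c1cc(OC)c(OC)c(OC)c1` gives 450 nM in this assay. Compound 1 carries the smaller number of the two, but the gap to compound 2 lies within the scatter, so the pair cannot be separated. For the measured compounds named here, no single-change step between measured compounds is available. Compound 3 `COc1ccc(CN(C(=O)C[Se]C#N)c2cc(OC)c(OC)c(OC)c2)cc1O` differs from compound 1 by a group of 4 heavy atoms (2 carbon, 1 nitrogen, 1 selenium; no ring) in place of a group of 4 heavy atoms (4 carbon; no ring), on a carbonyl carbon. Going by the values given here, with no measured step to lean on, only a modest move is expected, with a 1.3-fold lower number from compound 1 to compound 3 (0.11 log units; within the scatter) expected to stay near or just beyond the scatter. Compound 3 is therefore estimated at 250 nM in this assay, within 60 nM to 1000 nM.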

Compound 3, half-maximal inhibitory concentration: 270 nM
Compound 3: middle estimate off by 1.1-fold (0.03 log units), on the low side; the range from low to high includes it.
By their numbers in this assay, from the lowest: compounds 3, 1 and 2 (each within the scatter of the next).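

For the compounds shown here, on the carbonyl carbon, the 2-methylprop-1-en-1-yl group can be replaced by the selenium-containing nitrile group with a 1.2-fold lower number from compound 1 to compound 3 (0.07 log units; within the scatter) in this assay as the only single-change step at hand. Inhibition at this level therefore does not depend on the all-carbon alkene group at this position. No available data explain this tolerance.

On these data alone, whether the selenium or the nitrile matters remains open. A sulfur atom in place of the selenium, or a longer alkyl chain or an amine on the carbonyl carbon, would help to separate these contributions.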